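Aryl substituent variation on an anilinoquinazoline thioether series

The compounds below may be only part of what the source reports. "The series", "measured", "known", "first", "only" and "open" are said of these compounds alone.

Measured compounds:
compound 1 `FC(F)(F)c1ccc(CSc2nc(Nc3ccccc3)c3ccccc3n2)cc1` gives 18400 nM
compound 2 `Fc1ccc(Nc2nc(SCc3ccc(C(F)(F)F)cc3)nc3ccccc23)cc1` gives 15000 nM

Within the data shown here, compound 2 holds the lower of the two numbers in a functional assay on MDA-MB-231 cells (Homo sapiens) for cytotoxicity, read by MTT assay, with a stated time of 72 h (on this read-out lower numbers stand for stronger inhibition and higher numbers for weaker inhibition), with compound 1 the only neighbour, and the gap between them, a 1.2-fold lower number from compound 1 to compound 2 (0.09 log units; within the scatter), is not one that can be read as a difference in activity. Among the measured compounds shown here, that step, fluoro in place of hydrogen on an aromatic carbon, is the only measured change bearing on the present question.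

Compound 3 `FC(F)(F)c1ccc(CSc2nc(Nc3ccc(C(F)(F)F)cc3)c3ccccc3n2)cc1` is not yet measured. It differs from compound 2 by trifluoromethyl in place of fluoro on an aromatic carbon, para to a large group; cut one bond further out, the change reads 4-fluorophenyl to 4-(trifluoromethyl)phenyl.

For the measured compounds named here, since the one relevant step, a 1.2-fold lower number from compound 1 to compound 2 (0.09 log units; within the scatter), stayed within the scatter, no step beyond the scatter is expected here either. For compound 3 the estimated step is a 1.3-fold lower number from compound 2 to compound 3 (0.10 log units; within the scatter). Compound 3 is therefore expected to give about 12000 nM in this assay, with a plausible range from 5000 nM to 30000 nM.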

Compound 3, half-maximal inhibitory concentration: 5460 nM
Beside the measured number, compound 3's estimate is 2.2-fold (0.34 log units) above it; low and high end bracket the measured number.
By their numbers in this assay, from the lowest: compound 3; then compounds 2 and 1 (each within the scatter of the next).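

In this assay, the place para to a large group, on the phenyl of the (4-fluorophenyl)amino group, now turns out to be able to shift the number: trifluoromethyl in place of fluoro gives a 2.7-fold lower number from compound 2 to compound 3 (0.44 log units; beyond the scatter) and trifluoromethyl in place of hydrogen gives a 3.4-fold lower number from compound 1 to compound 3 (0.53 log units; beyond the scatter) in this series. The earlier step, a 1.2-fold lower number from compound 1 to compound 2 (0.09 log units; within the scatter), had not separated fluoro from hydrogen, whereas trifluoromethyl stands apart from both, though only modestly, and the numbers of all three compounds remain in the micromolar range. Nothing measured alongside these numbers accounts for the difference between trifluoromethyl and the two smaller substituents.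

On these data alone, whether a nitrile, a methoxy group or an amine at this same place would lower the number as trifluoromethyl does remains open, and with only three substituents at one place no trend across groups can be drawn. All three compounds share the rest of their structure and are read on one cell line, so whether the step holds with another group elsewhere on the shared core, or on other cells, is not shown.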